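The compounds below may be only part of what the source reports. "The series", "measured", "known", "first", "only" and "open" are said of these compounds alone.

In a functional assay on VCaP cells (Homo sapiens) for antiproliferative activity, read by CCK-8 assay, with a stated time of 6 days (on this read-out lower numbers stand for stronger inhibition and higher numbers for weaker inhibition), compound 1 `CCN(c1ccc(C#N)c(Cl)c1)c1cc(-n2cnc3ccccc32)ccc1C` gives 8560 nM as a measured value. Compound 2 `CCN(c1ccc(C#N)c(Cl)c1)c1cc(-c2ccc(F)nc2)ccc1C` shows only > 30000 nM in this read-out, and that is a limit of the assay, not a number. Compound 3 `CCN(c1ccc(C#N)c(Cl)c1)c1cc(-n2cccn2)ccc1C` keeps the shared core and changes one group, with 1H-pyrazol-1-yl in place of 6-fluoropyridin-3-yl (1H-pyrazol-1-yl in place of 6-fluoropyridin-3-yl on an aromatic carbon) on the same aromatic carbon. Among the compounds with values here, one measured step bears on this site: putting 6-fluoropyridin-3-yl in place of 1H-benzimidazol-1-yl gave an at least 3.5-fold higher number from compound 1 to compound 2 (0.54 log units; beyond the scatter) as a modest loss. Compound 3 also gives up the 6-fluoropyridin-3-yl group, so a lower number, meaning stronger inhibition, is expected, probably landing near compound 1 at 8560 nM and no lower by much. The estimate means an at least 2.5-fold lower number from compound 2 to compound 3 (0.39 log units; beyond the scatter) as the expected step, and it is uncertain since it starts from a limit. For compound 3 the expected value is 12000 nM with an estimated range of 4000 nM to 30000 nM in this assay.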

Compound 3, half-maximal inhibitory concentration: 2340 nM
Compound 3: middle estimate off by 5.1-fold (0.71 log units), on the high side; the whole stated range lies above it.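

Compound 3 shows in this assay that 1H-pyrazol-1-yl on this aromatic carbon does far better than 6-fluoropyridin-3-yl, with an at least 12-fold lower number from compound 2 to compound 3 (1.10 log units; beyond the scatter) as a large step. The same group also outperforms 1H-benzimidazol-1-yl, with a 3.7-fold lower number from compound 1 to compound 3 (0.56 log units; beyond the scatter) as a modest step beyond the scatter, which makes compound 3 the strongest of the three and shows that one five-membered aromatic ring with two hetero atoms can serve well at this site. Compound 2 carries a limit and not a number, so the larger step is only a minimum: the limit of > 30000 nM in this assay, at which 1 of the 3 values shown sits.

As far as these compounds go, whether the gain comes from the five-membered ring itself or from the placing of its hetero atoms stays open, as does the outcome with a phenyl or 1,2,4-triazol-1-yl group on this carbon. Also open, from the compounds shown here alone, is whether a methyl group or an amine on the pyrazole ring would lower the number further.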